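Swapping the oxane for an indole on the side chain

A few compounds are considered here, and "the series" means these few. Any claim that something is new, unique, unknown or untested is made for them only; others in the source may bear on it.

Compound 1 `CNC(=O)c1cc(C(=O)NC2CC2)cn(CC2CCCOC2)c1=O` is assessed in a physicochemical assay for lipophilicity, at pH 7.4 (on this read-out higher numbers stand for higher lipophilicity and lower numbers for lower lipophilicity), where compound 1 gives 2, the lowest of the three numbers recorded. Compound 3 `CNC(=O)c1cccn(Cc2ccccc2)c1=O` stands nearest to it, and compound 3 gives 3. Compound 2 `CNC(=O)c1cc(C(=O)NC2CCC2)cn(Cc2ccccc2)c1=O` lies furthest away, and compound 2 gives 3.8. Within the data shown here, the only single-point step among the measured compounds is a number 0.80 log units lower from compound 2 to compound 3 (beyond the scatter), which does not touch the position altered here. Compound 4 `CNC(=O)c1cc(C(=O)NC2CC2)cn(Cc2cccc3[nH]ccc23)c1=O` differs from compound 1 by 1H-indol-4-yl in place of oxan-3-yl on a saturated chain carbon bound to an aromatic nitrogen. Among the measured compounds shown here, no measured pair isolates this exchange; compound 2 and compound 1 differ in two places at once, so their values can only be noted side by side. With that reservation, compound 4 is expected to move by a number 1.20 log units higher from compound 1 to compound 4 (beyond the scatter), a rise beyond the scatter, since in this assay the benzyl-bearing compound 2 shows 3.8 against the lower reading of compound 1. Compound 4 is therefore estimated at 3.2, within a range from 2.6 to 3.8.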

Compound 4, distribution coefficient: 2.9
For compound 4 the middle estimate is 0.30 log units above the measured one, within the range that was stated.
By their numbers in this assay, from the lowest: compound 1; then compounds 4 and 3 (each within the scatter of the next); then compound 2.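

In this assay the exchange of oxan-3-yl for 1H-indol-4-yl on a saturated chain carbon bound to an aromatic nitrogen now has a direct reading: a number 0.90 log units higher from compound 1 to compound 4 (beyond the scatter). The earlier compounds shown here offered only a comparison across two places at once, whereas this pair changes that position alone and shows that the read-out responds to it by more than the scatter. No measurement explains the step, and the parts played by the larger group, its aromatic rings and its hydrogen-bond donor cannot be told apart.

On these data alone, it remains open how far the number would move with an amine or a carboxylic acid at this place. As far as these compounds go, it is also open whether the same exchange gives a similar step when cyclobutylcarbamoyl, the group carried by compound 2, stands elsewhere on the core.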